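A few compounds are considered here, and "the series" means these few. Any claim that something is new, unique, unknown or untested is made for them only; others in the source may bear on it.

In an assay on cell membranes for binding affinity to adenosine receptor A1 (Cavia porcellus), read by radioligand binding (on this read-out lower numbers stand for stronger inhibition and higher numbers for weaker inhibition), compound 1 `CCC(CC)Nc1ncnc2c1ncn2C1O[C@H](CO)[C@@H](O)[C@H]1O` gives 0.75 nM, compound 2 `CCCn1c(=O)c2nc([C@H]3CC4C=CC3C4)[nH]c2n(CCC)c1=O` gives 3.4 nM and compound 3 `CC(C)(C)CNc1ncnc2c1ncn2C1O[C@H](CO)[C@@H](O)[C@H]1O` gives 17 nM; compound 2 thus stands second highest of the three, nearest to compound 1 and furthest from compound 3. Compound 4 `CCCn1c(=O)c2nc(-c3cccn3C)[nH]c2n(CCC)c1=O` differs from compound 2 by a group of 6 heavy atoms (5 carbon, 1 nitrogen; one five-membered aromatic ring with 1 hetero atom) in place of a group of 7 heavy atoms (7 carbon; 2 five-membered non-aromatic rings of carbon only), on an aromatic carbon. The only single-point step known here, a 23-fold higher number from compound 1 to compound 3 (1.36 log units; beyond the scatter), concerns a different core and a different position, so no measured step bears directly on this change, and the replacement has no precedent among these numbers. Compound 4 is therefore expected to show only a modest rise from its parent, a 2.9-fold higher number from compound 2 to compound 4 (0.47 log units; beyond the scatter). The estimate for compound 4 is 10 nM, with a range from 2 nM to 60 nM.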

Compound 4, inhibition constant: 140 nM
For compound 4 the middle estimate is 14-fold (1.15 log units) below the measured one, outside the stated range (above it).
By their numbers in this assay, from the lowest: compound 1; then compound 2; then compound 3; then compound 4.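

At the aromatic carbon between two ring nitrogen atoms, the number in this assay proves highly sensitive to the group carried there: 1-methyl-1H-pyrrol-2-yl in place of the group with two five-membered non-aromatic rings of carbon only gives a 41-fold higher number from compound 2 to compound 4 (1.61 log units; beyond the scatter). Within the data shown here, this is the first measured change at this position, and it shows that the shared core alone does not hold the number low. Nothing available accounts for the size of this step. The compounds shown leave open whether the aromatic ring itself or the methyl on its nitrogen matters. An unsubstituted pyrrol-2-yl, a phenyl or a cyclopentyl at this carbon would separate these.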